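Nitrofuran chalcone: swapping tert-butyl for imidazolyl

This account rests on a few compounds, and the source may have more. Where it says the series, first, only, none or still open, it means among the compounds named here.

Measured compounds:
- compound 1 `CC(C)(C)c1ccc(C(=O)/C=C/c2ccc([N+](=O)[O-])o2)cc1`: > 100000 nM
- compound 2 `CC(C)(C)c1ccc(C(=O)/C=C/c2ccco2)cc1`: "not determined" (no result reported)

In an ADME assay on Vero cells (Chlorocebus sabaeus) for cytotoxicity, read by resazurin assay, with a stated time of 72 h (on this read-out higher numbers stand for lower toxicity in this test and lower numbers for higher toxicity in this test), compound 1 gives > 100000 nM. This figure is a limit of the assay and not a measured number; it marks (the limit of > 100000 nM in this assay, at which 1 of the 2 values shown sits). Among the compounds with values here, for compound 2 the result in this assay is "not determined" (no result reported), so no value is available for it, and no step between two measured compounds can be computed.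

Compound 3 `O=C(/C=C/c1ccc([N+](=O)[O-])o1)c1ccc(-n2ccnc2)cc1` keeps the core of compound 1 and changes one thing: 1H-imidazol-1-yl in place of tert-butyl on an aromatic carbon, on a six-membered aromatic ring of carbon only, para to a large group.

Within the data shown here, with no measured step to lean on, the only anchor is that compound 1 sits at the limit of this assay. The replacement is therefore expected to bring no shift beyond the usual scatter, so compound 3 is estimated at 120000 nM, with a range from 40000 nM to 300000 nM. The step that the limit leaves unreadable from compound 1 to compound 3 is an estimate, and a limit-only result is considered the most likely outcome.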

Compound 3, half-maximal cytotoxic concentration: > 100000 nM
Compound 3 was reported as a limit; the forecaster's own chance of this, stated with the estimate: 70%; the middle value lies beyond the limit too.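

Compound 3 gives > 100000 nM in this assay, and this is a limit of the assay, not a number. Compound 1 also stands at a limit, so no step between compound 1 and compound 3 can be read: the limit of > 100000 nM in this assay, at which 2 of the 3 values shown sit.

The compounds shown leave open whether 1H-imidazol-1-yl in place of tert-butyl changes cytotoxicity at all, since neither compound has an actual half-maximal value.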